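The source may report more compounds than this note shows. Statements on the series, on what has been measured and on what is new or still open speak of the compounds shown alone.

Working notes on the series, read in a physicochemical assay, read by spectrophotometry, with a stated time of 30 min; a lower number here means a stronger inhibitor, a higher number a weaker inhibitor. Compound 1 `O=C(CC(c1ccccc1Cl)c1c[nH]c2ccccc12)c1c(O)c2ccccc2oc1=O` gives 39.6 ug/mL, compound 2 `O=C(CC(c1c(Cl)cccc1Cl)c1c[nH]c2ccccc12)c1c(O)c2ccccc2oc1=O` gives 13.5 ug/mL and compound 3 `COc1ccc(C(CC(=O)c2c(O)c3ccccc3oc2=O)c2c[nH]c3ccccc23)c(OC)c1` gives 13.2 ug/mL. Compound 3 has the lowest of these numbers, but it cannot be separated from compound 2, as a 1.0-fold lower number from compound 2 to compound 3 (0.01 log units; within the scatter) shows. Only compound 1 stands apart from it, with a 3.0-fold lower number from compound 1 to compound 3 (0.48 log units; beyond the scatter).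

The next compound is compound 4 `COc1ccc(C(CC(=O)c2c(O)c3ccccc3oc2=O)c2c[nH]c3ccccc23)cc1OC`, which has the same atoms as compound 3, joined differently: 3,4-dimethoxyphenyl in place of 2,4-dimethoxyphenyl on a saturated chain carbon bound to an aromatic carbon and a saturated chain carbon.

Two measured steps change the aryl group at this same place. These are the modest 3.0-fold lower number from compound 1 to compound 3 (0.48 log units; beyond the scatter) and a 1.0-fold lower number from compound 2 to compound 3 (0.01 log units; within the scatter) already noted, which stays within the scatter. Adding chloro gives a 2.9-fold lower number from compound 1 to compound 2 (0.47 log units; beyond the scatter), also modest. Going by the values given here, no measured pair moves a methoxy group while keeping the group's identity, so the data give no direction for this change. Changes at this carbon have so far stayed modest, so a large move would be unexpected, and no step beyond the scatter is expected in this assay. The expected step is a 1.3-fold higher number from compound 3 to compound 4 (0.11 log units; within the scatter). The value estimated for compound 4 is 17 ug/mL, with an expected range from 8 ug/mL to 38 ug/mL.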

Compound 4, half-maximal inhibitory concentration: 63.2 ug/mL
Compound 4: middle estimate off by 3.7-fold (0.57 log units), on the low side, and the stated range ends below it.
By their numbers in this assay, from the lowest: compounds 3 and 2 (each within the scatter of the next); then compounds 1 and 4 (each within the scatter of the next).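

In this assay the arrangement of the methoxy groups on the aryl group at this saturated chain carbon matters, as a 4.8-fold higher number from compound 3 to compound 4 (0.68 log units; beyond the scatter) shows for a change that leaves the atoms and the counts of heavy atoms, donors and acceptors the same. Going by these compounds alone, this is the first step here that changes no atom, so composition alone does not set the reading at this place. Compound 4 also stands apart from compound 2, with a 4.7-fold higher number from compound 2 to compound 4 (0.67 log units; beyond the scatter) on record, while a 1.6-fold higher number from compound 1 to compound 4 (0.20 log units; within the scatter) stays within the scatter, so the four compounds fall into two sets, compounds 2 and 3 against compounds 1 and 4, and each set holds one chlorinated and one methoxylated aryl group; no information is available on the reason for this split.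

Still open, from the compounds shown here alone, is which of the two methoxy groups carries the step, a question that a phenyl bearing a single methoxy group could address. Also open, going by these compounds, is how a hydroxyl or an amine in place of a methoxy group on this aryl group would read in this assay against the same shared core.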